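Ring-amine methyl versus hydrogen in a bridged nicotinic series

This account rests on a few compounds, and the source may have more. Where it says the series, first, only, none or still open, it means among the compounds named here.

Measured compounds:
compound 1 `COc1cncc(C2=CC3CC(C2)CN(C)C3)c1` 2660 nM
compound 2 `Clc1ccc(C2=CC3CNCC(C2)C3)cn1` 54 nM
compound 3 `C1=C(c2cccnc2)C[C@H]2CNC[C@@H]1C2` 2.3 nM

In an in vitro functional assay on SH-EP1 cells for agonist activity at Neuronal acetylcholine receptor; alpha4/beta2 (Homo sapiens), read by FLIPR and calcium flux (a higher number here means that more compound is needed for the effect, a lower number that less compound is needed), compound 1 gives 2660 nM, the highest of the three numbers; compound 2 and compound 3 lie well beyond the scatter below it. Compound 4 `COc1cncc(C2=CC3CNCC(C2)C3)c1` differs from compound 1 by hydrogen in place of methyl on an amine nitrogen in a ring. Among the compounds with values here, no measured pair isolates this change. Within the data shown here, because compound 2 gives 54 nM and compound 3 gives 2.3 nM, both with hydrogen on the ring nitrogen, a large downward step is expected, though the methoxy-bearing ring of compound 1 has no measured counterpart with hydrogen. Compound 4 is estimated at 150 nM, range 30 nM to 800 nM, an expected step of an 18-fold lower number from compound 1 to compound 4 (1.25 log units; beyond the scatter).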

Compound 4, half-maximal effective concentration: 49 nM
Beside the measured number, compound 4's estimate is 3.1-fold (0.49 log units) above it; the measured number falls inside the stated range.
By their numbers in this assay, from the lowest: compound 3; then compounds 4 and 2 (each within the scatter of the next); then compound 1.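

In this assay, within the data shown here, hydrogen in place of methyl on an amine nitrogen in a ring gives a 54-fold lower number from compound 1 to compound 4 (1.73 log units; beyond the scatter), and this pair is the first to isolate the change. With the rest of the structure held constant, this single position carries a step beyond the scatter. Nothing at hand accounts for the size of this step.

Open, as far as these compounds go, is whether a step of this size also holds with the rings of compound 2 and compound 3. Also open, from the compounds shown here alone, is how an ethyl group or a longer chain on this nitrogen would read.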